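Swapping the fluorophenyl for a bromophenyl on the amine nitrogen

This account rests on a few compounds, and the source may have more. Where it says the series, first, only, none or still open, it means among the compounds named here.

compound 1, `Fc1ccc2nc(-c3ccccc3)nc(Nc3ccccc3)c2c1`: > 50000 nM
compound 2, `Fc1cccc(Nc2nc(-c3cccc(F)c3)nc3ccc(F)cc23)c1`: 47600 nM

In a functional assay on MDA-MB-231 cells (Homo sapiens) for cytotoxicity, read by MTT assay, with a stated time of 48 h (a lower number here means a stronger inhibitor, a higher number a weaker inhibitor), compound 1 gives > 50000 nM, which is a limit of the assay rather than a number. Compound 2 gives 47600 nM in this assay, and this is the only actual number shown; the other entry is the limit of > 50000 nM in this assay, at which 1 of the 2 values shown sits. Compound 2 is thus a weak inhibitor, standing close to the limit itself.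

Compound 3, `Fc1cccc(-c2nc(Nc3ccc(Br)cc3)c3cc(F)ccc3n2)c1`, has not yet been measured. It differs from compound 2 in one place: 4-bromophenyl in place of 3-fluorophenyl on a nitrogen on an aromatic ring. Among the compounds with values here, no two measured compounds differ in a single place, so no measured step shows how such a change moves the number. With compound 2 already near the limit, only a shift within the usual scatter is expected, in either direction. Compound 3 is expected to give 40000 nM in this assay, within a range of 15000 nM to 100000 nM. The expected step is a 1.2-fold lower number from compound 2 to compound 3 (0.08 log units; within the scatter), none beyond the scatter.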

Compound 3, half-maximal inhibitory concentration: > 50000 nM
Compound 3 gave a limit, no number; the forecaster's own chance of this, stated with the estimate: 45%; at least 1.2-fold (0.09 log units) between middle value and limit.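

Within the data shown here, at this position on the amine nitrogen, 4-bromophenyl in place of 3-fluorophenyl is the first single-place change that can be read, and in this assay it gives an at least 1.0-fold higher number from compound 2 to compound 3 (0.02 log units; that floor lies within the scatter). Going by these compounds, compound 3 stands at a limit of the assay rather than at a number, so the true size of this step stays unknown and it cannot be told apart from no change. What it does show is that this swap brought no clear drop in the number, and the compounds now gather at the top of the range: the limit of > 50000 nM in this assay, at which 2 of the 3 values shown sit.

Still open, on these data alone, is whether any group on this nitrogen can bring the number down clearly, such as a phenyl ring carrying a carboxylic acid or an amine, or a short alkyl chain in place of the ring. Also open, as far as these compounds go, is what a single change elsewhere on the shared core would do, since compound 1 differs from compound 2 in more than one place.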